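The source may hold more compounds than are shown below. What is called first, only, known or untested is meant among the compounds shown, and "the series" means these compounds.

In this assay, an assay on CHO cells with metabotropic glutamate receptor 5 (Homo sapiens) as the target (on this read-out higher numbers stand for an effect only at larger amounts of compound and lower numbers for an effect already at smaller amounts), compound 1 `O=C(Nc1cc(-c2ccccc2)nn1-c1ccccc1)c1ccc(F)c(F)c1` gives 10 nM, compound 2 `Cc1ccc(C(=O)Nc2cc(-c3ccccc3)nn2-c2ccccc2)cc1` gives 30 nM, and compound 3 `O=C(Nc1cc(-c2ccccc2)nn1-c1ccccc1)c1cnccn1` gives 200 nM. Compound 3 stands highest of the three numbers: the steps of a 20-fold higher number from compound 1 to compound 3 (1.30 log units; beyond the scatter) and a 6.7-fold higher number from compound 2 to compound 3 (0.82 log units; beyond the scatter) both lie beyond the scatter. Compound 4 `O=C(Nc1cc(-c2ccccc2)nn1-c1ccccc1)c1ccccc1O` differs from compound 3 in one place: 2-hydroxyphenyl in place of pyrazin-2-yl on a carbonyl carbon. The two measured steps at the same carbonyl carbon, a 20-fold higher number from compound 1 to compound 3 (1.30 log units; beyond the scatter) and a 6.7-fold higher number from compound 2 to compound 3 (0.82 log units; beyond the scatter), show that pyrazin-2-yl in place of a carbon-only aromatic ring raised the number in both cases, once largely and once modestly. Reversing that kind of change, a modest step down is expected for compound 4, a 5.0-fold lower number from compound 3 to compound 4 (0.70 log units; beyond the scatter). The estimate for compound 4 in this assay is 40 nM, with a range from 10 nM to 160 nM.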

Compound 4, half-maximal effective concentration: > 10000 nM
Compound 4: a limit, no number (the forecaster's own chance of this, stated with the estimate: 5%); at least 250-fold (2.39 log units) between middle value and limit.
By their numbers in this assay, from the lowest: compound 1; then compound 2; then compound 3. At a limit, above all of these: compound 4.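

In this assay compound 4 gives > 10000 nM, which is a limit and not a number. The steps of an at least 50-fold higher number from compound 3 to compound 4 (1.69 log units; beyond the scatter), an at least 330-fold higher number from compound 2 to compound 4 (2.52 log units; beyond the scatter) and an at least 1000-fold higher number from compound 1 to compound 4 (3.00 log units; beyond the scatter) are all large. A carbon-only aromatic ring at this carbonyl carbon therefore does not by itself keep the number low, and 2-hydroxyphenyl goes against the order suggested by compounds 1, 2 and 3. The compounds shown leave open whether the change follows from the hydroxy group specifically, and a 2-methoxyphenyl or 2-aminophenyl group at the same carbonyl carbon would bear on that.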